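Swapping the aryl group at the saturated ring carbon

The source may hold more compounds than are shown below. What is called first, only, known or untested is meant among the compounds shown, and "the series" means these compounds.

Compound 1 `N#CC1=C(N)N(c2ccc(S(N)(=O)=O)cc2)C2=C(C(=O)CCC2)C1/C=C/c1ccccc1` — 10%
Compound 2 `COc1ccccc1C1C(C#N)=C(N)N(c2ccc(S(N)(=O)=O)cc2)C2=C1C(=O)CCC2` — 0%
Compound 3 `N#CC1=C(N)N(c2ccc(S(N)(=O)=O)cc2)C2=C(C(=O)CCC2)C1c1ccc([N+](=O)[O-])cc1` — 80%

Of the compounds shown here, three sharing one core have been measured in a functional assay on Ehrlich cells (Mus musculus) for antiproliferative activity, read by trypan blue exclusion, with a stated time of 2 h, tested at 25 ug/mL; on this read-out higher numbers stand for a stronger effect at the one concentration tested and lower numbers for a weaker effect. Compound 3 gives 80% and stands highest of the three; compound 1 comes next with 10%, and compound 2 lies furthest away with 0%. Both steps into compound 3 are large: a number 70 percentage points higher from compound 1 to compound 3 (beyond the scatter), and a number 80 percentage points higher from compound 2 to compound 3 (beyond the scatter). The step between the two weaker compounds, a number 10 percentage points lower from compound 1 to compound 2 (within the scatter), is within the scatter.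

Compound 4 `N#CC1=C(N)N(c2ccc(S(N)(=O)=O)cc2)C2=C(C(=O)CCC2)C1c1ccc(Cl)cc1Cl` is not yet measured. It differs from compound 3 in one place: 2,4-dichlorophenyl in place of 4-nitrophenyl on a saturated ring carbon. The two large steps show that what sits on this saturated ring carbon decides whether the read-out is high or near zero, and only the 4-nitrophenyl group has given a high number. Among the compounds with values here, no measured step involves a 2,4-dichlorophenyl group, so the direction is open. Compound 4 is expected to fall between the two extremes, with a number 40 percentage points lower from compound 3 to compound 4 (beyond the scatter) as the most likely step downward from compound 3. Compound 4 is therefore estimated at 40%, with a range from 10% to 80%.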

Compound 4, a percentage reported as activity, at one concentration (the size of the read-out at that concentration, not a potency): 50%
Estimate against measurement, compound 4: 10 percentage points below; low and high end bracket the measured number.
By their numbers in this assay, from the lowest: compounds 2 and 1 (each within the scatter of the next); then compound 4; then compound 3.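

In this assay, within the data shown here, the 4-nitrophenyl group is no longer the only group on this saturated ring carbon to give a clear read-out: there is a number 50 percentage points higher from compound 2 to compound 4 (beyond the scatter) and a number 40 percentage points higher from compound 1 to compound 4 (beyond the scatter), so a high number here does not need a nitro group. The two groups are still not interchangeable, with a number 30 percentage points lower from compound 3 to compound 4 (beyond the scatter) when the 2,4-dichlorophenyl group enters, which shows a graded range at this position and not a simple split between high numbers and numbers near zero. Nothing available accounts for the order of these groups or for the size of the drop from the 4-nitrophenyl group.

The compounds shown change the substituent and its place on the phenyl ring together, so it stays open whether a 4-chlorophenyl group or a 4-methoxyphenyl group on this carbon would give a high number or one near zero. Every read-out comes from a single concentration, so these numbers give the size of the effect there and leave the potency of all four compounds open.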